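From Methoxy to Nitro in a Growth Inhibition Test

The source may hold more compounds than are shown below. What is called first, only, known or untested is meant among the compounds shown, and "the series" means these compounds.

In an ADME assay on HEK-293T cells (Homo sapiens) for inhibition, read by CCK-8 assay, with a stated time of 48 h, tested at 20 uM (a lower number here means less inhibition of growth, a higher number more inhibition of growth at the concentration tested), compound 1 `N#C/C(=C\c1ccccc1OS(=O)(=O)c1ccc([N+](=O)[O-])cc1)C(=O)Nc1nnc(Cc2ccc(F)cc2)s1` gives 8%, and compound 2 `COc1ccc(S(=O)(=O)Oc2ccccc2/C=C(\C#N)C(=O)Nc2nnc(Cc3ccc(Cl)cc3)s2)cc1` gives 26%. Compound 2 therefore stands higher of the two measured compounds, and the gap between them lies beyond the usual scatter.

The next compound to be tested, compound 3 `N#C/C(=C\c1ccccc1OS(=O)(=O)c1ccc([N+](=O)[O-])cc1)C(=O)Nc1nnc(Cc2ccc(Cl)cc2)s1`, is compound 2 with a single change: nitro in place of methoxy on an aromatic carbon. In words, nitro takes the place of methoxy on an aromatic carbon, so 4-methoxyphenyl becomes 4-nitrophenyl. For the measured compounds named here, the one measured compound that already carries 4-nitrophenyl is compound 1 at 8%. However, compound 1 also differs from compound 3 elsewhere, and the data cannot separate the effects of those two differences. A reasonable expectation is therefore that compound 3 lands somewhere between the two measured compounds. In this assay the expected change is a modest fall, estimated as a number 9 percentage points lower from compound 2 to compound 3 (within the scatter), and it may not clear the usual scatter. For compound 3 the estimated value is 17%, with an expected range from 4% to 35%.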

Compound 3, percent growth inhibition at one concentration: 19%
Compound 3: middle estimate off by 2 percentage points, on the low side, within the range that was stated.
By their numbers in this assay, from the lowest: compound 1; then compounds 3 and 2 (each within the scatter of the next).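

In this assay putting nitro in place of methoxy on this aromatic carbon, para to a large group, gives a number 7 percentage points lower from compound 2 to compound 3 (within the scatter) and so cannot be told apart from no change in this pair. For the compounds shown here, the same new compound also isolates a second single change, chloro in place of fluoro on an aromatic carbon, which gives a number 11 percentage points higher from compound 1 to compound 3 (beyond the scatter) and is the only one of the two steps that clears the usual spread of repeat measurements. The wider gap between the two earlier compounds, which differ in two places at once, can now be viewed one change at a time, although each step rests on a single pair and no measurement on hand explains the size of either one.

From the compounds shown here alone, it remains open whether an amine or a carboxylic acid in that same place on the ring would shift the reading any more than nitro does. Also open, going by these compounds, is whether a bromo group would continue the step seen from fluoro to chloro, and whether that step would look the same with 4-methoxyphenyl in place of 4-nitrophenyl.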